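Swapping chloro for iodo in compound 3

A few compounds are considered here, and "the series" means these few. Any claim that something is new, unique, unknown or untested is made for them only; others in the source may bear on it.

Compound 1 `C#C[C@@]1(O)[C@@H](CO)O[C@@H](n2cc(Br)c3c(N)ncnc32)[C@@H]1O`: 30 nM
Compound 2 `C#C[C@@]1(O)[C@@H](CO)O[C@@H](n2cc(I)c3c(N)ncnc32)[C@@H]1O`: 120 nM
Compound 3 `C#C[C@@]1(O)[C@@H](CO)O[C@@H](n2cc(Cl)c3c(Cl)ccnc32)[C@@H]1O`: 1300 nM

In a functional assay on CCRF-CEM cells (Homo sapiens) for antiproliferative activity, read by cell counting, with a stated time of 72 h (on this read-out lower numbers stand for stronger inhibition and higher numbers for weaker inhibition), compound 3 gives 1300 nM, the highest number of the three and so the weakest inhibition in this small set. The next compound, compound 4 `C#C[C@@]1(O)[C@@H](CO)O[C@@H](n2cc(I)c3c(Cl)ccnc32)[C@@H]1O`, keeps everything the same except for one group, with iodo in place of chloro on an aromatic carbon.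

Within the data shown here, only one measured step bears on this change. It is a 4.0-fold higher number from compound 1 to compound 2 (0.60 log units; beyond the scatter), a modest weakening beyond the scatter, seen when iodo replaces bromo on an aromatic carbon. That step is an imperfect guide. The halogen that leaves is a different one, and the core of compound 1 differs from the core of compound 3. Among the measured compounds shown here, no measured pair shows a swap of chloro for iodo directly, so both the size and the direction remain uncertain.

A modest move towards weaker inhibition in this assay is still the most reasonable expectation, estimated as a 1.9-fold higher number from compound 3 to compound 4 (0.28 log units; within the scatter). For compound 4 the expected value is 2500 nM. The estimated range runs from 700 nM to 9000 nM.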

Compound 4, half-maximal inhibitory concentration: 260 nM
For compound 4 the middle estimate is 9.6-fold (0.98 log units) above the measured one; the whole stated range lies above it.
By their numbers in this assay, from the lowest: compound 1; then compound 2; then compound 4; then compound 3.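

In this assay, putting iodo in place of chloro on this aromatic carbon of the five-membered ring gives a 5.0-fold lower number from compound 3 to compound 4 (0.70 log units; beyond the scatter), so on the core of compound 3 the larger halogen goes with stronger inhibition, by a margin beyond the usual scatter. Among these compounds, the only other halogen swap at this place, a 4.0-fold higher number from compound 1 to compound 2 (0.60 log units; beyond the scatter), runs the opposite way, with iodo replacing bromo on a different core, so these compounds show no single effect of iodo at this position: the result depends on the halogen that leaves, on the core, or on both, and the two steps cannot separate those possibilities. Nothing measured here explains why the two steps point in opposite directions.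

What the compounds shown leave open is where bromo would fall on the core of compound 3, and so whether chloro to bromo to iodo forms a steady series on that core or bromo stands out as it does beside iodo on the core of compound 1. They also leave open whether a group other than a halogen at this place, such as a methyl or a nitrile, would keep the inhibition seen with iodo.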